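Carbonyl substituent exchange at the piperidine amide of compound 3

The compounds below may be only part of what the source reports. "The series", "measured", "known", "first", "only" and "open" are said of these compounds alone.

Compound 3 `Cc1nc(S(C)(=O)=O)ccc1Oc1ncnc(OC2CCN(C(=O)SC3CC3)CC2)c1F` gives 80% in a functional assay on isolated protein for inhibition of Glucose-dependent insulinotropic receptor (Rattus norvegicus), read by HTRF and cAMP accumulation (a lower number here means a smaller maximal response, a higher number a larger maximal response), the second highest of the three numbers measured: compound 2 `Cc1nc(S(C)(=O)=O)ccc1Oc1ncnc(OC2CCN(C(=O)OC3(C(F)(F)F)COC3)CC2)c1F` gives 84%, and compound 1 `Cc1nc(S(C)(=O)=O)ccc1Oc1ncnc(OC2CCN(C(=O)OC3COC3)CC2)c1F` gives 66%. Compound 4 `Cc1nc(S(C)(=O)=O)ccc1Oc1ncnc(OC2CCN(C(=O)c3ncc(Cl)cn3)CC2)c1F` differs from compound 3 by a group of 7 heavy atoms (4 carbon, 2 nitrogen, 1 chlorine; one six-membered aromatic ring with 2 hetero atoms) in place of a group of 4 heavy atoms (3 carbon, 1 sulfur; one three-membered non-aromatic ring of carbon only), on a carbonyl carbon. Two earlier steps also changed the group on this carbonyl carbon: a number 14 percentage points higher from compound 1 to compound 3 (beyond the scatter) and a number 4 percentage points lower from compound 2 to compound 3 (within the scatter). Both stayed modest or within the scatter, so the carbonyl substituent has so far shifted the largest response only moderately; an aromatic group here has no precedent among these three compounds. Compound 4 is therefore expected to show a number 2 percentage points lower from compound 3 to compound 4 (within the scatter), and its estimated value is 78%, within a range from 58% to 96%.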

Compound 4, largest response reached (reported as efficacy), in percent of the reference or control that the assay uses: 77%
Beside the measured number, compound 4's estimate is 1 percentage points above it; measured number inside the range.
By their numbers in this assay, from the lowest: compound 1; then compounds 4, 3 and 2 (each within the scatter of the next).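

An aromatic group on this carbonyl carbon, 5-chloropyrimidin-2-yl, keeps the response in this assay level with the two best compounds, with a number 3 percentage points lower from compound 3 to compound 4 (within the scatter) and a number 7 percentage points lower from compound 2 to compound 4 (within the scatter) as the steps. With a number 11 percentage points higher from compound 1 to compound 4 (beyond the scatter) as the step from the (oxetan-3-yl)oxy group, compound 1 remains the only one set apart from the rest. Open, from the compounds shown here alone, is whether a pyrimidin-2-yl group lacking the chlorine, a simple amine or a longer alkyl chain on this carbonyl carbon would hold this response. No measurement shown here accounts for the similar responses of compounds 2, 3 and 4.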